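This account rests on a few compounds, and the source may have more. Where it says the series, first, only, none or still open, it means among the compounds named here.

Two compounds with a shared core, joined through a sulfur-linked chain to a dichlorophenyl amide, have been tested in an assay on 32D cells for inhibition of interleukin-15 (Mus musculus), read by resazurin assay, with stated times of 30 min and 2.5 days, in the presence of a further agent that is not named here; on this read-out higher numbers stand for weaker inhibition and lower numbers for stronger inhibition. Compound 1, `CCOC(CCn1c(Cc2nn(C)c(=O)c3ccccc23)nnc1SCC(=O)Nc1ccc(Cl)cc1Cl)OCC`, carries a diethoxypropyl group on the core and a short two-carbon link to the amide. In this assay compound 1 reaches only the assay limit of > 30000 nM, which is not a number but a ceiling of the measurement. Compound 2, `CN(C)CCCn1nc(Cc2nnc(SCCCCCCCC(=O)Nc3ccc(Cl)cc3Cl)n2C)c2ccccc2c1=O`, has a seven-carbon chain to the amide and a dimethylaminopropyl group on the core; in this assay compound 2 gives 2300 nM. For the measured compounds named here, that is the only actual number in hand, since the other result is the limit noted as the limit of > 30000 nM in this assay, at which 1 of the 2 values shown sits.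

Compound 3, `Cn1c(Cc2nn(CCC(=O)O)c(=O)c3ccccc23)nnc1SCCCCCCCC(=O)Nc1ccc(Cl)cc1Cl`, differs from compound 2 in one place: carboxy in place of (dimethylamino)methyl on a saturated chain carbon, two bonds along the chain from an aromatic nitrogen. Going by the values given here, no measured pair shows the effect of this change. The expectation is a modest loss, a 1.7-fold higher number from compound 2 to compound 3 (0.24 log units; within the scatter), so compound 3 is estimated at 4000 nM, between 1000 nM and 16000 nM.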

Compound 3, half-maximal inhibitory concentration: > 30000 nM
Compound 3 ended at the assay's limit; the forecaster's own chance of this, stated with the estimate: 25%; middle value at least 7.5-fold (0.87 log units) away from the limit.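

In this assay, for the compounds shown here, this is the first comparison of two compounds that differ in one place. It shows that the position on a saturated chain carbon, two bonds along the chain from an aromatic nitrogen, is sensitive to what it carries: carboxy in place of (dimethylamino)methyl gives an at least 13-fold higher number from compound 2 to compound 3 (1.11 log units; beyond the scatter). On these data alone, compound 1 and compound 2 differ in more than one place and could not isolate this change, while here the step lies beyond the usual scatter, although its full size stays unknown because compound 3 stands at a limit of the assay rather than at a number: the limit of > 30000 nM in this assay, at which 2 of the 3 values shown sit.

The compounds shown leave open whether the loss comes from removing the dimethylamino group or from adding the carboxy group, a question that a primary amine, a primary amide or a plain alkyl chain at this place could help to separate. They also leave open how much the chain leading to the amide contributes, as changing its length while keeping the 3-(dimethylamino)propyl group would test.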